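Amino substitution on the purine ring in two chloromethylbenzyl series

The compounds below may be only part of what the source reports. "The series", "measured", "known", "first", "only" and "open" are said of these compounds alone.

Compound 1 `ClCc1ccc(Cn2cnc3c(Cl)ncnc32)cc1` carries the chloromethyl group para on the benzyl ring; in a functional assay on SN12C cells (Homo sapiens) for cytotoxicity, read by sulforhodamine B assay, with a stated time of 48 h (a higher number here means that more compound is tolerated, a lower number that less compound is tolerated), compound 1 gives 5370 nM. Compound 2 `Nc1nc(Cl)c2ncn(Cc3ccc(CCl)cc3)c2n1` adds an amino group to the same core, the change being (amino in place of hydrogen on an aromatic carbon). In this assay compound 2 gives 60300 nM, so the step of an 11-fold higher number from compound 1 to compound 2 (1.05 log units; beyond the scatter) is a clear move toward more compound being tolerated.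

Compound 3 `ClCc1ccccc1Cn1cnc2c(Cl)ncnc21` is built from the same atoms as compound 1, joined differently; the difference between the two cores is not broken down here. In this assay compound 3 gives 95500 nM. Against compound 2 this is within the usual scatter, so no order between compound 2 and compound 3 is claimed; against compound 1 it lies beyond the scatter.

Compound 4 `Nc1nc(Cl)c2ncn(Cc3ccccc3CCl)c2n1` is not yet measured. It differs from compound 3 by amino in place of hydrogen on an aromatic carbon, and the place description matches that of the change from compound 1 to compound 2 word for word, so it is the same change. In this assay, within the data shown here, a step of about a 5.2-fold higher number from compound 3 to compound 4 (0.72 log units; beyond the scatter) is expected, resting on the single precedent an 11-fold higher number from compound 1 to compound 2 (1.05 log units; beyond the scatter). The start point is compound 3, which gives 95500 nM. Compound 4 is therefore estimated at 500000 nM, with a range from 150000 nM to 2000000 nM.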

Compound 4, concentration lethal to 50% of the cells: 19500 nM
The estimate for compound 4 lay 26-fold (1.41 log units) above the measured number, outside the stated range (below it).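

In this assay, amino in place of hydrogen on an aromatic carbon gives a 4.9-fold lower number from compound 3 to compound 4 (0.69 log units; beyond the scatter), a move in the opposite direction to the one on the core of compound 1, and the two steps clearly differ: the same change on two cores in this assay, an 11-fold higher number (1.05 log units; beyond the scatter) from compound 1 to compound 2 and a 4.9-fold lower number (0.69 log units; beyond the scatter) from compound 3 to compound 4, 55-fold (1.74 log units) apart, beyond the scatter of two such steps

This shows that, within this series, neither the size nor the direction of the step carries from one core to the other, even though the two cores are built from the same atoms joined differently. It does not show which feature of the cores separates the two outcomes, and with one pair on each core it gives no rule for any further core, only a warning against transferring a step from a single precedent.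

The compounds shown leave open whether a methylamino or a hydroxyl group in place of the amino group would also split between the two cores. They also leave open whether the opposite directions would persist if a bromomethyl or a hydroxymethyl group stood in place of the chloromethyl group.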